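The compounds below may be only part of what the source reports. "The series", "measured", "known", "first", "only" and "open" are said of these compounds alone.

In an ADME assay on L132 cells (Homo sapiens) for cytotoxicity, read by MTT assay, with a stated time of 72 h (on this read-out lower numbers stand for stronger inhibition and higher numbers for weaker inhibition), compound 1 `COc1ccc(C2=C(c3cc(OC)c(OC)c(OC)c3)C(=O)C(OC(C)=O)C2)cc1` gives > 100 ug/mL, which is a limit of the assay and not a number. Compound 2 `COc1ccc(C2=C(c3cc(OC)c(OC)c(OC)c3)C(=O)C(O)C2)cc1` gives < 1 ug/mL, also a limit. Going by the values given here, compound 3 `COc1ccc(C2=C(c3cc(OC)c(OC)c(OC)c3)C(=O)C(O[SiH2]C(C)(C)C)C2)cc1` gives 9 ug/mL, the only true number, which places it between the other two. Compound 4 `COc1cc(C2=C(c3ccc(SC)cc3)CC(O[SiH2]C(C)(C)C)C2=O)cc(OC)c1OC` has methylsulfanyl in place of methoxy on an aromatic carbon. The measured steps, an at least 100-fold lower number from compound 1 to compound 2 (2.00 log units; beyond the scatter), an at least 11-fold lower number from compound 1 to compound 3 (1.04 log units; beyond the scatter) and an at least 9.0-fold higher number from compound 2 to compound 3 (0.95 log units; beyond the scatter), were all large or at least modest, but all change the group on an oxygen on a saturated carbon. None tests this aromatic change, so no step beyond the scatter is expected in this assay, and no direction is favoured. The expected step is a 1.1-fold lower number from compound 3 to compound 4 (0.05 log units; within the scatter). Compound 4 is estimated at 8 ug/mL, with an expected range of 2.5 ug/mL to 30 ug/mL.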

Compound 4, half-maximal inhibitory concentration: < 1 ug/mL
Compound 4 was reported as a limit (the forecaster's own chance of this, stated with the estimate: 10%); middle value at least 8.0-fold (0.90 log units) away from the limit.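

Going by these compounds alone, all the earlier steps changed the group on the oxygen on a saturated carbon, so they said nothing about the aromatic ring. In this assay, putting methylsulfanyl in place of methoxy on that ring brings an at least 9.0-fold lower number from compound 3 to compound 4 (0.95 log units; beyond the scatter), which shows that this single-atom change on the aromatic carbon matters here too. Compound 4 sits at a limit of the assay and not at a number, so the full size of the step stays unknown: the limit of < 1 ug/mL in this assay, at which 2 of the 4 values shown sit.

On these data alone, whether an amine or a longer chain at this place would give a similar result remains open. So does whether the same change would count for as much on compound 2 or compound 1, with a different group on the oxygen.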